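Side-chain replacement at the saturated ring carbon: compound 4

The source may report more compounds than this note shows. Statements on the series, on what has been measured and on what is new or still open speak of the compounds shown alone.

Measured in an assay on CHO cells for displacement of a labelled ligand from 5-hydroxytryptamine receptor 1D (Homo sapiens); a higher number here means a weaker inhibitor, a lower number a stronger inhibitor:
- compound 1 `C[C@@H](NCC1CCN(CCCc2c[nH]c3ccc(-n4cnnc4)cc23)CC1)c1ccccc1` gives 1.4 nM
- compound 2 `O[C@H]1Cc2ccccc2C1NC1CCN(CCCc2c[nH]c3ccc(-n4cnnc4)cc23)CC1` gives 37 nM
- compound 3 `c1ccc2c(c1)CCC2NC1CCN(CCCc2c[nH]c3ccc(-n4cnnc4)cc23)CC1` gives 8.9 nM

Compound 1 has the lowest number of the three. The two steps away from it both alter the group on the saturated ring carbon and both raise the number: a 6.4-fold higher number from compound 1 to compound 3 (0.80 log units; beyond the scatter) and a 26-fold higher number from compound 1 to compound 2 (1.42 log units; beyond the scatter). The pair 2 and 3 separates out the hydroxy: a 4.2-fold lower number from compound 2 to compound 3 (0.62 log units; beyond the scatter).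

Compound 4 `CN(Cc1ccsc1)C1CCN(CCCc2c[nH]c3ccc(-n4cnnc4)cc23)CC1` differs from compound 1 in one place: methyl((thiophen-3-yl)methyl)amino in place of ((1-phenylethyl)amino)methyl on a saturated ring carbon. Both measured steps that bear on this position, 1>3 and 1>2, replace the ((1-phenylethyl)amino)methyl with an amino group held directly on the ring carbon, and both gave a higher number, modest in one case and large in the other. The change to compound 4 likewise removes the ((1-phenylethyl)amino)methyl and places a methyl((thiophen-3-yl)methyl)amino directly on the ring carbon, without the hydroxy that made step 1>2 large. A modest step to a higher number in this assay is therefore expected, with the wide range reflecting that neither measured step carries the same entering group.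

Compound 4 is estimated at 15 nM, expected between 3 nM and 70 nM, a step of an 11-fold higher number from compound 1 to compound 4 (1.03 log units; beyond the scatter).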

Compound 4, half-maximal inhibitory concentration: 1.5 nM
The estimate for compound 4 lay 10-fold (1.00 log units) above the measured number, and the stated range ends above it.
By their numbers in this assay, from the lowest: compounds 1 and 4 (each within the scatter of the next); then compound 3; then compound 2.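

In this assay, a 1.1-fold higher number from compound 1 to compound 4 (0.03 log units; within the scatter) shows that an amino group held on the saturated ring carbon does not in itself raise the number, and that neither the six-membered aromatic ring of carbon only nor the defined stereocentre of the ((1-phenylethyl)amino)methyl is required to stay level with compound 1. The entering group matters among the amino groups at this position: a 5.9-fold lower number from compound 3 to compound 4 (0.77 log units; beyond the scatter) separates compound 4 from the indanyl amine, and a 25-fold lower number from compound 2 to compound 4 (1.39 log units; beyond the scatter) separates it further from the hydroxylated one, so a change at this carbon can move the number in either direction depending on the group carried. The data at hand offer no measurement that accounts for these differences.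

Still open is which part of methyl((thiophen-3-yl)methyl)amino carries the result, since the pairs shown do not separate the methyl on the nitrogen from the thiophene. A secondary amine without that methyl, a benzyl group in place of the thiophen-3-ylmethyl, or a longer chain from the nitrogen to the thiophene would each test one of these parts on its own.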